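Swapping Bromine for Chlorine on the Aminomethylphenol Ring

The compounds below may be only part of what the source reports. "The series", "measured", "known", "first", "only" and "open" are said of these compounds alone.

Among the measured compounds shown here, compound 2 `COC(=O)/C=C/c1ccc(NCc2cc(Br)ccc2O)cc1` has the highest number of the two measured so far in a functional assay on HeLa cells (Homo sapiens) for antiproliferative activity, read by WST assay, with a stated time of 72 h (a higher number here means a weaker inhibitor, a lower number a stronger inhibitor), where compound 2 gives 7820 nM. Compound 1 `COC(=O)/C=C/c1ccc(NCc2ccccc2O)cc1` gives 7170 nM in this assay, so the two sit close together. Compound 3 `COC(=O)/C=C/c1ccc(NCc2cc(Cl)ccc2O)cc1` is not yet measured; it differs from compound 2 by chloro in place of bromo on an aromatic carbon. For the measured compounds named here, the only step that bears on this change is a 1.1-fold higher number from compound 1 to compound 2 (0.04 log units; within the scatter), which shows that adding the bromo group itself moved nothing beyond the scatter. The expected step is therefore a 1.0-fold lower number from compound 2 to compound 3 (0.02 log units; within the scatter). For compound 3 the estimate is 7500 nM, with a range from 3500 nM to 16000 nM.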

Compound 3, half-maximal inhibitory concentration: 8560 nM
Estimate against measurement, compound 3: 1.1-fold (0.06 log units) below; the measured number falls inside the stated range.
By their numbers in this assay, from the lowest: compounds 1, 2 and 3 (each within the scatter of the next).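

In this assay the swap at this position gives a 1.1-fold higher number from compound 2 to compound 3 (0.04 log units; within the scatter) and the comparison with the unsubstituted parent gives a 1.2-fold higher number from compound 1 to compound 3 (0.08 log units; within the scatter) so chloro, like bromo, leaves the number within the scatter. Hydrogen, bromo and chloro at this place, para to a hydroxy group, therefore cannot be told apart in this measurement. No data here offer an explanation for this flat result. On these data alone, whether an amine, a methoxy group or a carboxylic acid at this place would shift the number beyond the scatter remains open. So does the role of the hydroxy group, which all three compounds carry.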